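Methyl on the Core: Two Places, One Kind of Change

The compounds below may be only part of what the source reports. "The series", "measured", "known", "first", "only" and "open" are said of these compounds alone.

Of the compounds shown here, three have been measured in a functional assay on CAKI-1 cells (Homo sapiens) for antiproliferative activity; on this read-out lower numbers stand for stronger inhibition of growth and higher numbers for weaker inhibition of growth. Compound 1 `Cc1ccc2c(O)cc(-c3cccc(Cl)c3)nc2n1` gives 41.7 nM. Compound 3 `Cc1cc(C)c2c(O)cc(-c3cccc(Cl)c3)nc2n1` carries one more methyl group and gives 204 nM. Compound 2 `Oc1cc(-c2ccc3ccccc3c2)nc2ncccc12` gives 5620 nM, the highest number of the three. The difference between the core of compound 1 and the core of compound 2 is not broken down here.

For the measured compounds named here, the only counted step among the measured compounds is a 4.9-fold higher number from compound 1 to compound 3 (0.69 log units; beyond the scatter); the change is methyl in place of hydrogen on an aromatic carbon.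

Compound 4 `Cc1cnc2nc(-c3ccc4ccccc4c3)cc(O)c2c1` is not yet measured. It differs from compound 2 by methyl in place of hydrogen on an aromatic carbon. Going by the values given here, this is the same kind of change as the one from compound 1 to compound 3, but not the same: there the methyl sits ortho to a fused ring, meta to a methyl group and opposite the ring nitrogen, whereas here it sits two atoms from the ring nitrogen, meta and para to a fused ring. Among the compounds with values here, no measured pair shows a methyl at this place, so the expectation leans on the single measured step and on the weak starting point of compound 2. In this assay compound 4 is therefore expected to show a step of a 2.1-fold higher number from compound 2 to compound 4 (0.33 log units; beyond the scatter), most likely weaker than compound 2. The estimate for compound 4 is 12000 nM, with a range from 3500 nM to 40000 nM.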

Compound 4, concentration for 50% growth inhibition: 617 nM
Beside the measured number, compound 4's estimate is 19-fold (1.29 log units) above it; measured number below the stated range.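

In this assay the new step is a 9.1-fold lower number from compound 2 to compound 4 (0.96 log units; beyond the scatter), so methyl in place of hydrogen on an aromatic carbon does not move the number the same way on both cores. Set beside the earlier step, the change runs in the opposite direction, and the two steps clearly differ: the same change on two cores in this assay, a 4.9-fold higher number (0.69 log units; beyond the scatter) from compound 1 to compound 3 and a 9.1-fold lower number (0.96 log units; beyond the scatter) from compound 2 to compound 4, 45-fold (1.65 log units) apart, beyond the scatter of two such steps. What this does not show is whether the place of the methyl or the rest of the molecule decides the direction, as the methyl sits at a different place in each step and the two cores differ as well.

The compounds shown leave open what a methyl at the place it holds in compound 4, two atoms from the ring nitrogen, would do on the core of compound 1. They also leave open whether a longer chain, a methoxy group or an amine at that same place would keep the lower number seen for compound 4.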